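Closing the amine side chain into a hydroxypyrrolidine ring

The compounds below may be only part of what the source reports. "The series", "measured", "known", "first", "only" and "open" are said of these compounds alone.

Measured so far:
- compound 1, `COc1cc[nH]c1/C=C1\C(=O)Nc2ccc(F)c(C#C[C@H](N)CO)c21`, in a functional assay on MDA-MB-435 cells (Homo sapiens) for inhibition; on this read-out higher numbers stand for weaker inhibition and lower numbers for stronger inhibition: 320 nM
- compound 2, `COc1cc[nH]c1/C=C1\C(=O)Nc2ccc(F)c(C#C[C@H](CO)NCCO)c21`, in this assay: 1270 nM

Compound 2 holds the higher of the two numbers, meaning the weaker inhibition of the pair. Going by the values given here, the only measured step is a 4.0-fold higher number from compound 1 to compound 2 (0.60 log units; beyond the scatter), which replaces a primary amine bearing a hydroxymethyl group with one that also carries a hydroxyethyl group on the nitrogen.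

Compound 3, `COc1cc[nH]c1/C=C1\C(=O)Nc2ccc(F)c(C#C[C@@H]3C[C@H](O)CN3)c21`, has not yet been measured. It differs from compound 2 in this way: 4-hydroxypyrrolidin-2-yl in place of 2-hydroxy-1-((2-hydroxyethyl)amino)ethyl on a triple-bonded carbon. The amine and its carbon chain are thus tied into a five-membered ring carrying one hydroxyl group, while the triple bond and the shared core stay unchanged.

Among the compounds with values here, no measured step makes the same kind of change, so the step from compound 1 to compound 2 is only a loose guide. Since compound 3 keeps a secondary amine, as compound 2 does, but loses one hydroxyl-bearing chain, a number between those of compound 1 and compound 2 is expected, and the estimated step is a 2.1-fold lower number from compound 2 to compound 3 (0.33 log units; beyond the scatter). For compound 3 in this assay the expected value is 600 nM, with a range from 150 nM to 2500 nM.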

Compound 3, half-maximal inhibitory concentration: 110 nM
For compound 3 the middle estimate is 5.5-fold (0.74 log units) above the measured one, outside the stated range (below it).
By their numbers in this assay, from the lowest: compound 3; then compound 1; then compound 2.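

In this assay, tying the amine and its carbon chain into the 4-hydroxypyrrolidin-2-yl ring gives a 12-fold lower number from compound 2 to compound 3 (1.06 log units; beyond the scatter) and also a 2.9-fold lower number from compound 1 to compound 3 (0.46 log units; beyond the scatter) so compound 3 is the strongest inhibitor of the three, and both gaps are beyond the usual scatter. This shows that the triple-bonded carbon can carry a ring as well as an open chain, and that the ring does better here than either open chain. Compound 2 and compound 3 both hold a secondary amine, so among these compounds a carbon substituent on the nitrogen does not by itself go with a weaker inhibition, as the step from the primary amine alone might have suggested. No measured information is available here to explain why the ring gives this gain.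

The compounds shown leave open how a plain pyrrolidin-2-yl ring without the hydroxyl, a six-membered piperidine ring or a methoxy group on the ring would compare with compound 3. They also leave open how much the two defined stereocentres of the ring matter, since only one arrangement of them appears here.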